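Working notes: from compound 2 to compound 3

The compounds below may be only part of what the source reports. "The series", "measured", "known", "first", "only" and "open" are said of these compounds alone.

Two compounds have numbers in an in vitro assay on CHOK cells for displacement of a labelled ligand from growth hormone secretagogue receptor type 1 (Homo sapiens); on this read-out lower numbers stand for stronger inhibition and higher numbers for weaker inhibition. Compound 1 `Nc1nc(N)c(-c2ccc(NCc3ccnc(Cl)c3)cc2)c(COCc2ccccc2)n1` gives 1.5 nM in this assay. Compound 2 `COc1ccc(CNc2ccc(-c3c(N)nc(N)nc3COCc3ccccc3)cc2)cc1` gives 7.7 nM, the higher of the two numbers; the step of a 5.1-fold higher number from compound 1 to compound 2 (0.71 log units; beyond the scatter) separates them. Compound 3 `Nc1nc(N)c(-c2ccc(NCc3ccncc3)cc2)c(COCc2ccccc2)n1` carries pyridin-4-yl in place of 4-methoxyphenyl on a saturated chain carbon bound to a nitrogen on an aromatic ring. Within the data shown here, the only step bearing on this change is a 5.1-fold higher number from compound 1 to compound 2 (0.71 log units; beyond the scatter), which ran in the opposite sense at the same place, and compound 3 carries pyridin-4-yl where compound 1 carries 2-chloropyridin-4-yl. A move back toward compound 1 is therefore expected, as a 2.6-fold lower number from compound 2 to compound 3 (0.41 log units; beyond the scatter). Compound 3 is estimated at 3 nM, with a range from 1 nM to 10 nM.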

Compound 3, half-maximal inhibitory concentration: 21 nM
For compound 3 the middle estimate is 7.0-fold (0.85 log units) below the measured one; measured number above the stated range.
By their numbers in this assay, from the lowest: compound 1; then compound 2; then compound 3.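

At this place, on a saturated chain carbon bound to a nitrogen on an aromatic ring, pyridin-4-yl in place of 4-methoxyphenyl gives in this assay (a 2.7-fold higher number from compound 2 to compound 3 (0.44 log units; beyond the scatter)). Hydrogen in place of chloro on an aromatic carbon gives a larger change (a 14-fold higher number from compound 1 to compound 3 (1.15 log units; beyond the scatter)), so the advantage of 2-chloropyridin-4-yl over 4-methoxyphenyl does not survive loss of the chloro. No available evidence bears on either step.

Going by these compounds, it remains open whether bromo, methyl or an amine in place of the chloro would hold the low number, and whether a chloro added to the 4-methoxyphenyl ring would shift the number in the same direction.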